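The compounds below may be only part of what the source reports. "The series", "measured", "known", "first", "only" and "open" are said of these compounds alone.

Three compounds sharing the core of compound 1 `O=C1O[C@H]([C@@H](O)Cn2cc(-c3ccc(Br)cc3)nn2)C(OCc2ccccc2)=C1OCc1ccccc1` have been tested in a functional assay on HeLa cells (Homo sapiens) for antiproliferative activity, read by MTT assay, with a stated time of 72 h; a higher number here means a weaker inhibitor, a lower number a stronger inhibitor. Compound 1 gives 3910 nM, compound 2 `O=C1O[C@H]([C@@H](O)Cn2cc(-c3cc(C(F)(F)F)cc(C(F)(F)F)c3)nn2)C(OCc2ccccc2)=C1OCc1ccccc1` gives 35500 nM, and compound 3 `CCCCCc1ccc(-c2cn(C[C@H](O)[C@H]3OC(=O)C(OCc4ccccc4)=C3OCc3ccccc3)nn2)cc1` gives 8390 nM. Compound 3 therefore stands second highest of the three numbers, closest to compound 1 and furthest from compound 2. Among the compounds with values here, the only single-place step measured so far is a 2.1-fold higher number from compound 1 to compound 3 (0.33 log units; beyond the scatter). Compound 4 `O=C1O[C@H]([C@@H](O)Cn2cc(CNS(=O)(=O)c3ccc(Cl)cc3)nn2)C(OCc2ccccc2)=C1OCc1ccccc1` differs from compound 3 by (((4-chlorophenyl)sulfonyl)amino)methyl in place of 4-pentylphenyl on an aromatic carbon. Within the data shown here, no measured step exchanges the whole aromatic group for a chain carrying a sulfonamide, so nothing bears directly on this change, and the one step available was modest. For compound 4 the expected step is a 1.1-fold higher number from compound 3 to compound 4 (0.03 log units; within the scatter). Compound 4 is estimated at 9000 nM, with a range from 2000 nM to 40000 nM.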

Compound 4, half-maximal inhibitory concentration: 13600 nM
The estimate for compound 4 lay 1.5-fold (0.18 log units) below the measured number; the measured number falls inside the stated range.
By their numbers in this assay, from the lowest: compound 1; then compounds 3 and 4 (each within the scatter of the next); then compound 2.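

Replacing a group at this aromatic carbon need not change the readout much: in this assay, swapping 4-pentylphenyl for (((4-chlorophenyl)sulfonyl)amino)methyl gives a 1.6-fold higher number from compound 3 to compound 4 (0.21 log units; within the scatter) and so stays within the scatter, although the entering group brings a sulfonamide. The same group replacing 4-bromophenyl gives a 3.5-fold higher number from compound 1 to compound 4 (0.54 log units; beyond the scatter) and lies beyond the scatter, so compound 1 keeps the lower number. Nothing available explains either step.
Open, on these data alone, is how a simple amine or a carboxylic acid at this aromatic carbon would compare, and whether the chloro on the sulfonyl-bearing ring contributes to the value of compound 4.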